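This account rests on a few compounds, and the source may have more. Where it says the series, first, only, none or still open, it means among the compounds named here.

Of the compounds shown here, three sharing one core have been measured in an assay on HEK293 cells for positive allosteric modulation of metabotropic glutamate receptor 5 (Homo sapiens), read by FLIPR; on this read-out higher numbers stand for an effect only at larger amounts of compound and lower numbers for an effect already at smaller amounts. Compound 1 `O=C(C1CCC2(CCC2)CC1)N1CC(c2nc(-c3cccc(Cl)c3)no2)C1` gives 1100 nM in this assay. Compound 2 `O=C(c1ccc(F)cc1)N1CC(c2nc(-c3cccc(F)c3)no2)C1` gives 2400 nM in this assay. Compound 3 `COC1CCCN(C(=O)N2CC(c3nc(-c4cccc(Cl)c4)no3)C2)C1` reaches only the limit of this assay, > 10000 nM, so no number is known for it. Compound 3 stands at the limit of > 10000 nM in this assay, at which 1 of the 3 values shown sits. Going by the values given here, the only measured step that ends at compound 3 is an at least 9.0-fold higher number from compound 1 to compound 3 (0.95 log units; beyond the scatter), which places the 3-methoxypiperidin-1-yl amide at the limit while the spiro carbocyclic amide of compound 1 gives a number.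

Compound 4 `O=C(c1ccc(F)cc1)N1CC(c2nc(-c3cccc(Cl)c3)no2)C1` is still to be measured in this assay. It differs from compound 3 by 4-fluorophenyl in place of 3-methoxypiperidin-1-yl on a carbonyl carbon. Among the compounds with values here, no measured step covers exactly this exchange. The step of an at least 9.0-fold higher number from compound 1 to compound 3 (0.95 log units; beyond the scatter) bears on it in reverse, showing that a different amide substituent in place of 3-methoxypiperidin-1-yl gives a value within range. Compound 2 carries the same 4-fluorophenyl amide on a closely related core and gives 2400 nM in this assay, so the 4-fluorophenyl amide is compatible with a measurable effect. The analysis therefore expects a step of an at least 6.6-fold lower number from compound 3 to compound 4 (0.82 log units; beyond the scatter) toward a lower number, beyond the scatter. Compound 4 is expected to give about 1500 nM, with a range from 500 nM to 5000 nM.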

Compound 4, half-maximal effective concentration: > 10000 nM
Compound 4: a limit, no number; the forecaster's own chance of this, stated with the estimate: 10%; middle value at least 6.6-fold (0.82 log units) away from the limit.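

In this assay compound 4 gives only a limit of the assay and no number, so the 4-fluorophenyl amide does not keep a value within range on the core that carries chloro: the limit of > 10000 nM in this assay, at which 2 of the 4 values shown sit.

With that amide kept, chloro in place of fluoro on an aromatic carbon is an at least 4.1-fold higher number from compound 2 to compound 4 (0.61 log units; beyond the scatter), so this aromatic position matters and the value of compound 2 does not carry over to its chloro counterpart. On the chloro core, the change of amide group gives an at least 9.0-fold higher number from compound 1 to compound 4 (0.95 log units; beyond the scatter), which leaves the group of compound 1 as the only one of the three amide groups there with a number, while the step between the two limits of compound 3 and compound 4 cannot be read.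

Going by these compounds, it remains open whether a plain cyclohexyl amide, which lacks the four-membered ring of compound 1, would also give a number on the chloro core. On these data alone, it is equally open whether bromo or methyl in place of fluoro on that aromatic carbon would keep a number with the 4-fluorophenyl amide.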